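The compounds below may be only part of what the source reports. "The series", "measured", "known", "first", "only" and "open" are said of these compounds alone.

In an ADME assay on MDCKII-LE cells (Canis lupus familiaris) for permeability, read by transwell migration, in the apical to basolateral direction (a lower number here means that the compound crosses the layer more slowly, a higher number that the compound crosses the layer faster), compound 1 (`NC(=O)[C@@H](CCC(F)(F)F)N(CC1COC1)S(=O)(=O)c1ccc(Cl)cc1`) gives 25.4 10^-6 cm/s, compound 2 (`CC1(C)C[C@@H](CN([C@H](CCC(F)(F)F)C(N)=O)S(=O)(=O)c2ccc(Cl)cc2)O1`) gives 14.9 10^-6 cm/s and compound 3 (`NC(=O)[C@@H](CCC(F)(F)F)N(C[C@H]1CCCCO1)S(=O)(=O)c1ccc(Cl)cc1`) gives 13.4 10^-6 cm/s, so compound 3 stands within the scatter of both others. Compound 4 (`NC(=O)[C@@H](CCC(F)(F)F)N(C[C@H]1COCCO1)S(=O)(=O)c1ccc(Cl)cc1`) differs from compound 3 in one place: 1,4-dioxan-2-yl in place of oxan-2-yl on a saturated chain carbon bound to a sulfonamide nitrogen. Three measured steps exchange the group at this same place: a 1.7-fold lower number from compound 1 to compound 2 (0.23 log units; within the scatter), a 1.9-fold lower number from compound 1 to compound 3 (0.28 log units; within the scatter) and a 1.1-fold lower number from compound 2 to compound 3 (0.05 log units; within the scatter). All three stay within the scatter, although none is this exact exchange. The expected 1.1-fold lower number from compound 3 to compound 4 (0.05 log units; within the scatter) is therefore no larger than the scatter, with no direction favoured. For compound 4 the estimated value is 12 10^-6 cm/s, with an expected range from 6.5 10^-6 cm/s to 21 10^-6 cm/s.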

Compound 4, apparent permeability: 20.6 10^-6 cm/s
The estimate for compound 4 lay 1.7-fold (0.23 log units) below the measured number; the range from low to high includes it.
By their numbers in this assay, from the lowest: compounds 3, 2, 4 and 1 (each within the scatter of the next).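

In this assay, 1,4-dioxan-2-yl in place of oxan-2-yl gives a 1.5-fold higher number from compound 3 to compound 4 (0.19 log units; within the scatter), while the same group gives a 1.4-fold higher number from compound 2 to compound 4 (0.14 log units; within the scatter) and a 1.2-fold lower number from compound 1 to compound 4 (0.09 log units; within the scatter) when it replaces the other two rings. A six-membered ring with 2 hetero atoms is therefore also accommodated at this place, and all four compounds remain within the scatter of one another. Nothing available explains these small differences. On these data alone, it remains open whether an amine or a carboxylic acid on this saturated chain carbon would also stay within the scatter.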